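Chloro to Bromo on the Phenyl Ring

The compounds below may be only part of what the source reports. "The series", "measured", "known", "first", "only" and "open" are said of these compounds alone.

Measured in a functional assay on PC-3 cells (Homo sapiens) for inhibition, read by MTT assay, with a stated time of 72 h; a lower number here means a stronger inhibitor, a higher number a weaker inhibitor:
compound 1 `C#CCSc1nc(Nc2ccc(C)cc2)c2ccncc2n1` gives 15700 nM
compound 2 `C#CCSc1nc(Nc2ccc(F)cc2)c2ccncc2n1` gives 17300 nM
compound 3 `C#CCSc1nc(Nc2ccc(Cl)cc2)c2ccncc2n1` gives 19000 nM

Among the measured compounds shown here, all three share one core and differ only in the single group on the phenyl ring. The steps among them are small: a 1.1-fold higher number from compound 1 to compound 2 (0.04 log units; within the scatter), a 1.2-fold higher number from compound 1 to compound 3 (0.08 log units; within the scatter) and a 1.1-fold higher number from compound 2 to compound 3 (0.04 log units; within the scatter), each within the scatter. Compound 3 therefore sits inside a tight cluster, its number closest to that of compound 2 and a little further from that of compound 1, but no ranking of the three can be read from gaps this small.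

Compound 4 `C#CCSc1nc(Nc2ccc(Br)cc2)c2ccncc2n1` has not yet been measured in this assay. It differs from compound 3 in one place: bromo in place of chloro on an aromatic carbon. For the measured compounds named here, the steps that bear on this change are the earlier halogen swaps, which moved the number by amounts inside the scatter, so a further exchange of one halogen for another is expected to do the same. In this assay compound 4 is expected to give about 19000 nM, within a range of 10000 nM to 38000 nM. The expected step is no change at the digits printed from compound 3 to compound 4 (within the scatter), that is, nothing beyond the scatter.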

Compound 4, half-maximal inhibitory concentration: 26000 nM
Compound 4: middle estimate off by 1.4-fold (0.14 log units), on the low side; low and high end bracket the measured number.
By their numbers in this assay, from the lowest: compounds 1, 2, 3 and 4 (each within the scatter of the next).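

Bromo in place of chloro gives a 1.4-fold higher number from compound 3 to compound 4 (0.14 log units; within the scatter) and the comparisons with the other two groups give a 1.5-fold higher number from compound 2 to compound 4 (0.18 log units; within the scatter) and a 1.7-fold higher number from compound 1 to compound 4 (0.22 log units; within the scatter) in this assay for this same position on the phenyl ring. Even the widest of these steps stays inside the scatter, so methyl and all three halogens tried here remain unseparated, and the position has so far shown no sensitivity to swaps among these four groups. No information is available here to explain these numbers.

As far as these compounds go, whether a group of a different kind at this position, such as an amine, a carboxylic acid or a methoxy group, would move the number beyond the scatter stays open. Also open, from the compounds shown here alone, is whether a longer chain elsewhere on the shared core would do so.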